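Amide for Amide on a Fused Hydroxy Core

A few compounds are considered here, and "the series" means these few. Any claim that something is new, unique, unknown or untested is made for them only; others in the source may bear on it.

Measured so far:
compound 1, `Nc1ccc(O)c2ccncc12`: 19000 nM
compound 2, `NC(=O)c1ccc(O)c2ccccc12`: 430000 nM
compound 3, `Nc1ccc(CO)c2ccccc12`: 1000000 nM

In a functional assay, with a stated time of 15 min (a lower number here means that less compound is needed, a higher number that more compound is needed for the effect), compound 2 stands second highest of the three numbers: compound 3 gives a higher number, compound 1 a far lower one, and both gaps lie beyond the scatter. Compound 4, `CCC(=O)Nc1ccc(O)c2ccccc12`, has not yet been measured in this assay. It differs from compound 2 in one place: propanoylamino in place of carbamoyl on an aromatic carbon. Compound 4 keeps the hydroxy group that compound 1 also carries, and compound 1 gives the lowest number shown, so a step toward a lower number is expected in this assay, though only a modest one. The expected step of a 2.9-fold lower number from compound 2 to compound 4 (0.46 log units; beyond the scatter) leads to an estimate for compound 4 of 150000 nM, within a range from 30000 nM to 600000 nM.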

Compound 4, half-maximal effective concentration: 16000 nM
Compound 4: the middle estimate sits 9.4-fold (0.97 log units) above what was measured, outside the stated range (below it).
By their numbers in this assay, from the lowest: compounds 4 and 1 (each within the scatter of the next); then compound 2; then compound 3.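

In this assay, propanoylamino in place of carbamoyl on this aromatic carbon, para to a hydroxy group, gives a 27-fold lower number from compound 2 to compound 4 (1.43 log units; beyond the scatter) and so marks this position as highly responsive to the group it carries. Both groups count one hydrogen-bond donor and one hydrogen-bond acceptor, so those counts alone do not set the number here. Nothing measured here accounts for the step.

On these data alone, it remains open whether a shorter acetylamino group or a longer butanoylamino chain would lower the number further or raise it. As far as these compounds go, whether a plain amine at this position would retain the step also remains open.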